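Swapping a hydroxyphenyl for a chlorophenyl on the urea

The source may report more compounds than this note shows. Statements on the series, on what has been measured and on what is new or still open speak of the compounds shown alone.

Compound 3 `COc1cc(NC(C)CCCNC(=O)Nc2cccc(O)c2)c2ncccc2c1` gives 24000 nM in a functional assay on MOLT-4 cells (Homo sapiens) for inhibition, read by MTT assay, with a stated time of 72 h; on this read-out higher numbers stand for weaker inhibition and lower numbers for stronger inhibition. Of the three compounds measured, compound 3 stands second highest: compound 2 `COc1cc(NC(C)CCCNC(=O)Nc2cccc(F)c2)c2ncccc2c1` gives 23000 nM, and the two lie within the scatter of each other, while compound 1 `COc1cc(NC(C)CCCNC(=O)NNC(=O)Nc2cccc(Cl)c2)c2ncccc2c1` gives 93000 nM, separated by a 3.9-fold lower number from compound 1 to compound 3 (0.59 log units; beyond the scatter). The new compound 4 `COc1cc(NC(C)CCCNC(=O)Nc2ccc(Cl)cc2)c2ncccc2c1` differs from compound 3 by 4-chlorophenyl in place of 3-hydroxyphenyl on an amide-type nitrogen. The step that bears on it most closely is a 1.0-fold higher number from compound 2 to compound 3 (0.02 log units; within the scatter), showing that hydroxy in place of fluoro changed little; the step of a 4.0-fold lower number from compound 1 to compound 2 (0.61 log units; beyond the scatter) concerns a different change and bears less. Compound 4 is therefore expected to differ from compound 3 by a 1.1-fold lower number from compound 3 to compound 4 (0.04 log units; within the scatter), a step within the scatter. Compound 4 is estimated at 22000 nM, with a range from 9000 nM to 55000 nM.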

Compound 4, half-maximal inhibitory concentration: 24000 nM
Beside the measured number, compound 4's estimate is 1.1-fold (0.04 log units) below it; the measured number falls inside the stated range.
By their numbers in this assay, from the lowest: compounds 2, 3 and 4 (each within the scatter of the next); then compound 1.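

In this assay, the earlier pair showed only that hydroxy and fluoro match at one ring position; the 4-chlorophenyl group now shows that the number also holds when the substituent and its ring position both change, with no change at the digits printed from compound 3 to compound 4 (within the scatter) and a 1.0-fold higher number from compound 2 to compound 4 (0.02 log units; within the scatter). This holds even though 4-chlorophenyl has none of the hydrogen-bond donors or acceptors counted on 3-hydroxyphenyl. The gap to the longer group of compound 1 remains, with a 3.9-fold lower number from compound 1 to compound 4 (0.59 log units; beyond the scatter). Nothing measured here offers an explanation for this flat result. Still open, from the compounds shown here alone, is whether a phenyl ring carrying an amine or a carboxylic acid, or a benzyl group on this nitrogen, would move the number.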